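The source may hold more compounds than are shown below. What is called first, only, known or untested is meant among the compounds shown, and "the series" means these compounds.

Measured so far:
compound 1 `C=CC1=C(C(=O)NCc2ccc(C)cc2)C(c2ccc(F)cc2)OC1` — > 100000 nM
compound 2 `C=CC1=C(C(=O)NC2CCCCC2)C(c2ccc(OC)c(OC)c2)OC1` — 19100 nM

Compound 1 `C=CC1=C(C(=O)NCc2ccc(C)cc2)C(c2ccc(F)cc2)OC1` and compound 2 `C=CC1=C(C(=O)NC2CCCCC2)C(c2ccc(OC)c(OC)c2)OC1` share the core but differ in more than one place, so their two values are only set side by side. In a functional assay on SW480 cells (Homo sapiens) for cytotoxicity, read by MTT assay, with a stated time of 24 h (a higher number here means a weaker inhibitor, a lower number a stronger inhibitor), compound 1 gives > 100000 nM, which is a limit of the assay and not a number. Compound 2 gives 19100 nM in this assay. Compound 1 thus stands at the limit of > 100000 nM in this assay, at which 1 of the 2 values shown sits; nothing more than that limit is known for it.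

Compound 3 `C=CC1=C(C(=O)Nc2cccc(C)c2)C(c2ccc(F)cc2)OC1` is not yet measured. It differs from compound 1 in one place: 3-methylphenyl in place of 4-methylbenzyl on an amide-type nitrogen. For the measured compounds named here, no step between measured compounds bears on this change, so the only anchor is the limit for compound 1. For this assay the expectation is no step beyond the scatter, with compound 3 staying near that limit. Compound 3 is therefore estimated at 100000 nM in this assay, within 30000 nM to 400000 nM. The estimated step of a number no higher from compound 1 to compound 3 (the limit leaves the size open) is expected to be small, and the assay may again report only a limit.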

Compound 3, half-maximal inhibitory concentration: > 100000 nM
Compound 3 was reported as a limit; the forecaster's own chance of this, stated with the estimate: 65%; the middle value sits exactly at the limit.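

For the compounds shown here, compound 1 and compound 3 are both reported only as limits of the assay in this assay, so no step between them can be read. Still open, on these data alone, is what 3-methylphenyl in place of 4-methylbenzyl on an amide-type nitrogen does to cytotoxicity in this assay.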